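From amino to hydroxy on the cyclohexyl ring

This account rests on a few compounds, and the source may have more. Where it says the series, first, only, none or still open, it means among the compounds named here.

Measured so far:
Compound 1 `NC1CCC(Nc2nc(NCc3ccc(-c4ccccc4)cc3)c3ncn(C4CCCC4)c3n2)CC1` gives 240 nM
Compound 2 `NC1CCC(Nc2nc(NCc3ccc(-c4ccco4)cc3)c3ncn(C4CCCC4)c3n2)CC1` gives 71 nM
Compound 3 `NC1CCC(Nc2nc(NCc3ccc(-c4ccco4)nc3)c3ncn(C4CCCC4)c3n2)CC1` gives 30 nM

In a functional assay on HeLa cells (Homo sapiens) for inhibition, with a stated time of 72 h (a higher number here means a weaker inhibitor, a lower number a stronger inhibitor), compound 3 has the lowest number of the three, with a 2.4-fold lower number from compound 2 to compound 3 (0.37 log units; beyond the scatter) as its smallest gap and an 8.0-fold lower number from compound 1 to compound 3 (0.90 log units; beyond the scatter) as its largest. Compound 4 `OC1CCC(Nc2nc(NCc3ccc(-c4ccco4)nc3)c3ncn(C4CCCC4)c3n2)CC1` differs from it in a single group: hydroxy in place of amino on a saturated ring carbon (hydroxy in place of amino on a saturated ring carbon, so that 4-aminocyclohexyl becomes 4-hydroxycyclohexyl).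

Among the compounds with values here, none of the measured steps touches this place. All three keep the 4-aminocyclohexyl group, so they give no direct reading of its replacement and serve only as a gauge of size. The smallest of them is a 2.4-fold lower number from compound 2 to compound 3 (0.37 log units; beyond the scatter) and the largest is an 8.0-fold lower number from compound 1 to compound 3 (0.90 log units; beyond the scatter) in the same series, with a 3.4-fold lower number from compound 1 to compound 2 (0.53 log units; beyond the scatter) lying in the middle. The data therefore do not settle the direction. Compound 3 already sits lowest at 30 nM and a modest step towards a higher number is expected, with no change still possible. The estimated step is a 3.0-fold higher number from compound 3 to compound 4 (0.48 log units; beyond the scatter) (modest, and uncertain in size). For compound 4 the estimated value is 90 nM (expected range 30 nM to 300 nM).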

Compound 4, half-maximal inhibitory concentration: 247 nM
Beside the measured number, compound 4's estimate is 2.7-fold (0.44 log units) below it; measured number inside the range.
By their numbers in this assay, from the lowest: compound 3; then compound 2; then compounds 1 and 4 (each within the scatter of the next).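

In this assay, within the data shown here, replacing 4-aminocyclohexyl with 4-hydroxycyclohexyl gives an 8.2-fold higher number from compound 3 to compound 4 (0.92 log units; beyond the scatter), the first reading of this position, which the earlier steps left untouched, and it shows that the position affects the read-out. The step is about as large as the largest earlier one, an 8.0-fold lower number from compound 1 to compound 3 (0.90 log units; beyond the scatter), although here a single nitrogen gives way to a single oxygen, and the counts of hydrogen-bond donors and acceptors and the net charge stay the same on both sides. No measurement available here bears on why the number rises so far.

With only the amino and hydroxy groups represented at this place, the compounds shown leave open how a methylamino group, a dimethylamino group, an aminomethyl group or a carboxylic acid on the cyclohexyl ring would read. They also leave open whether the same change from amino to hydroxy would give a step of similar size with the 4-phenylphenyl group of compound 1 or the 4-(furan-2-yl)phenyl group of compound 2 in place of the 6-(furan-2-yl)pyridin-3-yl group.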